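Nitro for methoxy: what compound 4 may give

The compounds below may be only part of what the source reports. "The series", "measured", "known", "first", "only" and "open" are said of these compounds alone.

In a functional assay on the whole organism (Tail) with Rattus norvegicus as the target, in the tail flick test, with a stated time of 60 min, at a dose of 25 mg/kg by the oral route (a lower number here means less inhibition, a higher number more inhibition at the dose given (going by the name of the read-out)), the three measured compounds gave:
Compound 1, `Fc1ccc(C2=NN(c3ccccc3)C(c3cn(-c4ccccc4)nc3-c3ccc(Cl)cc3)C2)cc1`: 43%
Compound 2, `Fc1ccc(C2=NN(c3ccccc3)C(c3cn(-c4ccccc4)nc3-c3ccc(Br)cc3)C2)cc1`: 71%
Compound 3, `COc1ccc(-c2nn(-c3ccccc3)cc2C2CC(c3ccc(F)cc3)=NN2c2ccccc2)cc1`: 66%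

Compound 3 stands second highest of the three; the step of a number 5 percentage points lower from compound 2 to compound 3 (within the scatter) lies within the scatter, while the step of a number 23 percentage points higher from compound 1 to compound 3 (beyond the scatter) is modest but real. Compound 4, `O=[N+]([O-])c1cccc(-c2nn(-c3ccccc3)cc2C2CC(c3ccc(F)cc3)=NN2c2ccccc2)c1`, differs from compound 3 by 3-nitrophenyl in place of 4-methoxyphenyl on an aromatic carbon. Within the data shown here, no measured step swaps this group for a nitro-bearing ring, so the nearest guides are a number 28 percentage points higher from compound 1 to compound 2 (beyond the scatter) and a number 23 percentage points higher from compound 1 to compound 3 (beyond the scatter), both modest exchanges of the group at this ring carbon. Compound 4 is therefore expected to stay close to compound 3, with an estimated step of a number 8 percentage points lower from compound 3 to compound 4 (within the scatter), within the scatter. Compound 4 is estimated at 58%, with a range from 38% to 76%.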

Compound 4, a percentage reported as inhibition, in the whole organism at one dose (the size of the read-out at that dose, not a potency): 108%
Compound 4: the middle estimate sits 50 percentage points below what was measured; measured number above the stated range.
By their numbers in this assay, from the lowest: compound 1; then compounds 3 and 2 (each within the scatter of the next); then compound 4.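

In this assay, among these compounds, the exchanges among the earlier compounds at this aromatic carbon gave modest steps at most, but 3-nitrophenyl gives large ones: a number 42 percentage points higher from compound 3 to compound 4 (beyond the scatter), a number 37 percentage points higher from compound 2 to compound 4 (beyond the scatter) and a number 65 percentage points higher from compound 1 to compound 4 (beyond the scatter). The group at this carbon can therefore shift the read-out much further than compounds 1, 2 and 3 showed. Nothing at hand bears on why the read-out rises so far. As far as these compounds go, whether the rise goes with the nitro group itself or with its place on the phenyl ring stays open, as does what an amine or a carboxylic acid on that ring would give.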